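This account rests on a few compounds, and the source may have more. Where it says the series, first, only, none or still open, it means among the compounds named here.

In a functional assay on G-361 cells (Homo sapiens) for cytotoxicity, read by fluorescence, with a stated time of 72 h (a higher number here means a weaker inhibitor, a lower number a stronger inhibitor), two compounds sharing one core have been measured so far. Compound 1 `CC(C)c1n[nH]c2c(NCc3ccc(-c4ccccn4)cc3)nc(NCC(N)CO)nc12`, which carries a 1-amino-2-hydroxyethyl group on a saturated chain carbon, gives 1020 nM. Compound 2 `COc1ccc(CNc2nc(NCc3ccc(-c4ccccn4)cc3)c3[nH]nc(C(C)C)c3n2)cc1`, with a 4-methoxyphenyl group in that place, gives 7490 nM, the higher of the two numbers and therefore the weaker result. Among the compounds with values here, that swap is the only measured step, a 7.3-fold higher number from compound 1 to compound 2 (0.87 log units; beyond the scatter), and it lies beyond the scatter.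

Compound 3 `CC(C)c1n[nH]c2c(NCc3ccc(-c4ccccn4)cc3)nc(NCc3ccc(-c4ccccn4)cc3)nc12` differs from compound 2 at a single place: pyridin-2-yl in place of methoxy on an aromatic carbon. Pyridin-2-yl replaces methoxy on an aromatic carbon, which turns 4-methoxyphenyl into 4-(pyridin-2-yl)phenyl. The measured step bears on this only loosely. It replaced 1-amino-2-hydroxyethyl with an aromatic group, whereas here one aromatic group gives way to a larger one. Within the data shown here, no measured pair shows this exact change, and no step beyond the scatter is expected in this assay. The expected change is a 1.2-fold higher number from compound 2 to compound 3 (0.08 log units; within the scatter). For compound 3 the estimated value is 9000 nM, with an expected range from 3000 nM to 27000 nM.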

Compound 3, half-maximal inhibitory concentration: 3610 nM
The estimate for compound 3 lay 2.5-fold (0.40 log units) above the measured number; the measured number falls inside the stated range.
By their numbers in this assay, from the lowest: compound 1; then compound 3; then compound 2.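

In this assay the swap of methoxy for pyridin-2-yl gives a 2.1-fold lower number from compound 2 to compound 3 (0.32 log units; beyond the scatter), a modest step but one beyond the scatter. It shows that the aromatic carbon para to a large group is not a silent spot, and that a second aromatic ring there goes with a lower number than methoxy does, which the earlier pair, changing a whole side group at once, could not show. Even so, the gain does not recover what the aromatic side groups lose, since the comparison with the 1-amino-2-hydroxyethyl group gives a 3.5-fold higher number from compound 1 to compound 3 (0.55 log units; beyond the scatter) and leaves compound 1 with the lowest number of the three, though no measurement shown here accounts for either step.

From the compounds shown here alone, whether the lower number belongs to the added ring itself or to its nitrogen stays open, and a plain phenyl group at the same place would separate the two. Going by these compounds, it is equally open whether the amine or the hydroxyl of the 1-amino-2-hydroxyethyl group matters more, which a simple 2-hydroxyethyl or 2-aminoethyl chain would begin to answer.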